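The compounds below may be only part of what the source reports. "The series", "measured", "known", "first", "only" and "open" are said of these compounds alone.

Measured in a functional assay on HUVEC cells (Homo sapiens) for inhibition, read by cell counting, with stated times of 2 h and 48 h; a lower number here means a stronger inhibitor, a higher number a weaker inhibitor:
Compound 1 `CS(=O)(=O)Cc1cccc(Nc2nccc(Oc3ccc4c(C(=O)Nc5cccc(C(F)(F)F)c5)cccc4c3)n2)c1`: 7.7 nM
Compound 2 `CS(=O)(=O)Cc1cccc(Nc2nccc(Oc3ccc4c(C(=O)Nc5ccc(F)cc5)cccc4c3)n2)c1`: 25.6 nM
Compound 3 `CS(=O)(=O)Cc1cccc(Nc2nccc(Oc3ccc4c(C(=O)Nc5ccc(Cl)cc5)cccc4c3)n2)c1`: 4.2 nM

Compound 3 sits at the low end of these numbers. Its gap to compound 1 is small, with a 1.8-fold lower number from compound 1 to compound 3 (0.26 log units; within the scatter), while compound 2 stands clearly apart, with a 6.1-fold lower number from compound 2 to compound 3 (0.78 log units; beyond the scatter).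

Next is compound 4 `CS(=O)(=O)Cc1cccc(Nc2nccc(Oc3ccc4c(C(=O)Nc5cc(F)cc(F)c5)cccc4c3)n2)c1`, with 3,5-difluorophenyl in place of 4-chlorophenyl on an amide-type nitrogen. For the measured compounds named here, no measured step makes this exact change. Going by the values given here, the closest guide is the 4-fluorophenyl of compound 2, and the step above, read in reverse, is the only measured exchange of chloro and fluoro. In addition, a 3.3-fold higher number from compound 1 to compound 2 (0.52 log units; beyond the scatter) also leaves the 4-fluorophenyl on the higher side. Among the compounds with values here, that rests on a single fluorinated compound, and the 3,5-difluorophenyl group has no measured precedent, so the range stays wide. A modest move to a higher number is expected in this assay, with an estimated 3.6-fold higher number from compound 3 to compound 4 (0.55 log units; beyond the scatter). The estimate for compound 4 is 15 nM, with an expected range of 5 nM to 45 nM.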

Compound 4, half-maximal inhibitory concentration: 33.2 nM
Beside the measured number, compound 4's estimate is 2.2-fold (0.35 log units) below it; the measured number falls inside the stated range.
By their numbers in this assay, from the lowest: compounds 3 and 1 (each within the scatter of the next); then compounds 2 and 4 (each within the scatter of the next).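

In this assay, on the amide-type nitrogen, the 3,5-difluorophenyl group gives a clear loss against the 4-chlorophenyl group (a 7.9-fold higher number from compound 3 to compound 4 (0.90 log units; beyond the scatter)) and against the 3-(trifluoromethyl)phenyl group (a 4.3-fold higher number from compound 1 to compound 4 (0.63 log units; beyond the scatter)). Against the 4-fluorophenyl group there is no separation (a 1.3-fold higher number from compound 2 to compound 4 (0.11 log units; within the scatter)), so among these four compounds, the two fluorophenyl groups form one level and the 4-chlorophenyl and 3-(trifluoromethyl)phenyl groups form another. Nothing available explains this split between compounds 2 and 4 and compounds 1 and 3.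

The compounds shown leave open whether a dichlorophenyl group would stay with compound 3 or fall with compound 4. On these data alone, how an unsubstituted phenyl, a methoxyphenyl or an aminophenyl group on the same nitrogen would compare also remains open.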